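The compounds below may be only part of what the source reports. "The series", "measured", "known", "first", "only" and "open" are said of these compounds alone.

Measured so far:
compound 1, `CS(=O)(=O)c1ccc(-c2cnc3[nH]cc(-c4nnc(-c5ccc(Cl)cc5)o4)c(=O)c3c2)cc1`, 11.3%;
compound 2, `CS(=O)(=O)c1ccc(-c2cnc3[nH]cc(-c4nnc(-c5ccc(F)cc5)o4)c(=O)c3c2)cc1`, 9.45%;
compound 3, `CS(=O)(=O)c1ccc(-c2cnc3[nH]cc(-c4nnc(-c5ccncc5)o4)c(=O)c3c2)cc1`, 3.49%.

All three numbers come from a functional assay on HepG2 cells (Homo sapiens) for inhibition, read by MTT assay, with a stated time of 24 h, tested at 5 uM; a higher number here means more inhibition of growth at the concentration tested, a lower number less inhibition of growth. Compound 1 has the highest of the three, but the gaps are small: a number 1.9 percentage points lower from compound 1 to compound 2 (within the scatter) and a number 7.8 percentage points lower from compound 1 to compound 3 (within the scatter), and likewise a number 6 percentage points lower from compound 2 to compound 3 (within the scatter), so none of the three can be set apart from the others.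

Compound 4, `O=c1c(-c2nnc(-c3ccc(Cl)cc3)o2)c[nH]c2ncc(-c3ccccc3)cc12`, has not yet been measured. It differs from compound 1 in one place only: hydrogen in place of methylsulfonyl on an aromatic carbon. The group that leaves sits on an aromatic carbon of a six-membered aromatic ring of carbon only, para to a large group.

For the measured compounds named here, none of the measured steps touches this position; all of them exchange the aryl group at the other end of the shared core, and every one of them stayed within the scatter. Going by the values given here, there is therefore no measured step that bears directly on removing the methylsulfonyl group, and the only guide is that the series as a whole has moved little. The expectation for this assay is a step of no more than the usual scatter, written as a number 2.3 percentage points lower from compound 1 to compound 4 (within the scatter), with no preferred direction. For compound 4 the estimate is 9%, expected to fall between 0% and 22%.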

Compound 4, percent growth inhibition at one concentration: 5.1%
Estimate against measurement, compound 4: 3.9 percentage points above; measured number inside the range.
By their numbers in this assay, from the lowest: compounds 3, 4, 2 and 1 (each within the scatter of the next).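

In this assay, for the compounds shown here, there is a number 6.2 percentage points lower from compound 1 to compound 4 (within the scatter) when 4-(methylsulfonyl)phenyl becomes phenyl, and this is the first measured change at this position, since compound 1, compound 2 and compound 3 differ only in another aryl group. Taking the methylsulfonyl group off this aromatic carbon and leaving a bare hydrogen therefore gives no step beyond the scatter, so at this single concentration the reading does not show that the group matters, and a second site in the molecule now joins the first in showing no step that can be told from repeat-to-repeat variation. Nothing measured here speaks to why the reading behaves this way.

The compounds shown leave open whether a different group on this carbon, such as an amine or a carboxylic acid, would give a step beyond the scatter. They also leave open whether removing the methylsulfonyl group would read the same with the 4-fluorophenyl or pyridin-4-yl group in place of the 4-chlorophenyl group that compound 4 keeps from compound 1.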